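Moving the methyl on the amine-bound phenyl ring

The source may report more compounds than this note shows. Statements on the series, on what has been measured and on what is new or still open speak of the compounds shown alone.

Measured compounds:
Compound 1, `Cc1cccc(N(C)CC2CCC/C(=C\c3ccccc3)C2=O)c1`: 44.9%
Compound 2, `Cc1ccc(N(C)CC2CCC/C(=C\c3ccc(S(C)(=O)=O)cc3)C2=O)cc1`: 27%

Of the compounds shown here, two have been tested in a functional assay on the whole organism (Ear, strain Kunming) for inhibition, with Mus musculus as the target, with stated times of 1 h and 30 min, at a dose of 200 mg/kg by the oral route; a lower number here means less inhibition, a higher number more inhibition at the dose given (going by the name of the read-out). Compound 1 gives 44.9%, and compound 2 gives 27%. Compound 2 thus stands lowest of the two numbers; its nearest neighbour is compound 1, which lies higher by a gap that is beyond the usual scatter. Compound 1 and compound 2 differ in more than one place, so the two values do not isolate any single structural contribution.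

The next compound, compound 3, `Cc1cccc(N(C)CC2CCC/C(=C\c3ccc(S(C)(=O)=O)cc3)C2=O)c1`, has not yet been measured in this assay. It differs from compound 2 in one place: 3-methylphenyl in place of 4-methylphenyl on an amine nitrogen. The same atoms are present; they are joined differently. Within the data shown here, since no single-change step between measured compounds exists, the expectation for this change rests only on the two values above. The step from compound 2 to compound 3 is expected to be small and upward, a number 6 percentage points higher from compound 2 to compound 3 (within the scatter), and may not exceed the scatter. Compound 3 is therefore estimated at 33%, within a range from 18% to 48%.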

Compound 3, a percentage reported as inhibition, in the whole organism at one dose (the size of the read-out at that dose, not a potency): 36.7%
Beside the measured number, compound 3's estimate is 3.7 percentage points below it; the range from low to high includes it.
By their numbers in this assay, from the lowest: compounds 2, 3 and 1 (each within the scatter of the next, the first and the last beyond it).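

Among these compounds, the first single-place steps are now available, and neither is large. In this assay, moving the methyl on the amine nitrogen's aryl group, 3-methylphenyl in place of 4-methylphenyl, gives a number 9.7 percentage points higher from compound 2 to compound 3 (within the scatter), so with methylsulfonyl present on the other aromatic ring, these two arrangements of the same atoms cannot be told apart in this read-out. Methylsulfonyl in place of hydrogen on an aromatic carbon, with 3-methylphenyl held constant, gives a number 8.2 percentage points lower from compound 1 to compound 3 (within the scatter), so this change cannot be told apart from the hydrogen either, and nothing shown explains either step.

The compounds shown leave open whether a larger step would follow from a methoxy group or a chlorine atom in place of the methyl on the phenyl ring bound to the amine nitrogen. They also leave open how a sulfonamide or a carboxylic acid would read in place of methylsulfonyl on that aromatic carbon.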